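The source may hold more compounds than are shown below. What is called first, only, known or untested is meant among the compounds shown, and "the series" means these compounds.

Three members of this series have been run through an assay on isolated protein for inhibition of Nitric oxide synthase, inducible (Homo sapiens), read by scintillation counting, with a stated time of 30 min, tested at 50 uM (on this read-out lower numbers stand for less inhibition and higher numbers for more inhibition at the one concentration tested (going by the name of the read-out)), and a fourth awaits the same test. Compound 1 `CC1(C)SC(c2cc(Cl)ccc2N)=NN1C(=O)C1CCC1` gives -4.65% in this assay. Compound 2 `CC1(C)SC(c2cc(Cl)ccc2N)=NN1C(=O)C1CCCC1` gives 21.3%. Compound 3 `CC1(C)SC(c2ccccc2N)=NN1C(=O)C1CCC1`, which carries no chloro on the ring, gives 46.9% and stands highest of the three, with its steps to both others beyond the scatter.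

Two single changes connect these numbers. The step of a number 26 percentage points higher from compound 1 to compound 2 (beyond the scatter) comes with the change (cyclopentyl in place of cyclobutyl on a carbonyl carbon). The step of a number 51.6 percentage points higher from compound 1 to compound 3 (beyond the scatter) comes with the change (hydrogen in place of chloro on an aromatic carbon), which is also how the core of compound 1 differs from the core of compound 3.

Compound 4 `CC1(C)SC(c2ccccc2N)=NN1C(=O)C1CCCC1` has not yet been measured. It is reached from compound 3 by the change (cyclopentyl in place of cyclobutyl on a carbonyl carbon), the same change that links compound 1 to compound 2, at a place described in the same words. Across the compounds shown this change occurs twice. On the basis of that single earlier step, compound 4 is expected to sit a step of about a number 23.1 percentage points higher from compound 3 to compound 4 (beyond the scatter) above compound 3 in this assay, with the caveat that the change has been seen only once and on a different core. Compound 4 is thus estimated to give 70%, with a likely range from 48% to 90%.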

Compound 4, a percentage reported as inhibition, at one concentration (the size of the read-out at that concentration, not a potency): 42.2%
For compound 4 the middle estimate is 27.8 percentage points above the measured one; measured number outside the range, below it.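

In this assay, the cyclopentyl-for-cyclobutyl change on the core of compound 3 gives a number 4.7 percentage points lower from compound 3 to compound 4 (within the scatter), so the rise seen on the chloro-bearing core did not carry over to the core without the chloro: the same change on two cores in this assay, a number 26 percentage points higher (beyond the scatter) from compound 1 to compound 2 and a number 4.7 percentage points lower (within the scatter) from compound 3 to compound 4, 30.7 percentage points apart, beyond the scatter of two such steps The other change, hydrogen in place of chloro on an aromatic carbon, gives a number 20.9 percentage points higher from compound 2 to compound 4 (beyond the scatter), which keeps the direction of the earlier step but not its size: the same change on two cores in this assay, a number 51.6 percentage points higher (beyond the scatter) from compound 1 to compound 3 and a number 20.9 percentage points higher (beyond the scatter) from compound 2 to compound 4, 30.7 percentage points apart, beyond the scatter of two such steps Across these four compounds, then, the size of a step at one place depends on what sits at the other, and a step measured on one core is a poor guide to its size on another, although this rests on one pair of steps for each change and does not show why the two cores differ.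

The compounds shown leave open how a cyclohexyl group or an open chain on the carbonyl carbon would read on either core, and whether a bromo or methoxy group in place of the chloro would depress the number as the chloro does here. They also leave open whether the order seen at this single concentration would hold for true potencies.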